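Bromo to trifluoromethyl on the pendant phenyl: cytotoxicity notes

A few compounds are considered here, and "the series" means these few. Any claim that something is new, unique, unknown or untested is made for them only; others in the source may bear on it.

Measured so far in an ADME assay on HeLa cells (Homo sapiens) for cytotoxicity, read by MTT assay; on this read-out lower numbers stand for stronger inhibition and higher numbers for weaker inhibition:
Compound 1 `N#Cc1c(-c2ccccc2Br)c(C#N)c(=O)n(/N=C/c2cn(-c3ccccc3)nc2-c2ccccc2)c1N` gives > 200 ug/mL, which is a limit of the assay.
Compound 2 `N#Cc1c(-c2ccc(Br)cc2)c(C#N)c(=O)n(/N=C/c2cn(-c3ccccc3)nc2-c2ccccc2)c1N` gives > 200 ug/mL, likewise a limit.

Compound 2 thus stands at the limit in this assay, not at a number. Going by the values given here, the one further value shown, that of compound 1, is also a limit. Both sit at the limit of > 200 ug/mL in this assay, at which 2 of the 2 values shown sit. The step that the two limits leave unreadable from compound 1 to compound 2 therefore has no readable size.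

Compound 3 `N#Cc1c(-c2ccc(C(F)(F)F)cc2)c(C#N)c(=O)n(/N=C/c2cn(-c3ccccc3)nc2-c2ccccc2)c1N` differs from compound 2 by trifluoromethyl in place of bromo on an aromatic carbon. Among the compounds with values here, no measured step covers this change, and the single neighbouring step, from compound 1 to compound 2, gives no size to lean on. Compound 3 is expected to stay at the limit in this assay, with an estimated step that the limit leaves unreadable from compound 2 to compound 3 that is unlikely to exceed the scatter. Compound 3 is estimated at 250 ug/mL, within 100 ug/mL to 600 ug/mL.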

Compound 3, half-maximal inhibitory concentration: > 200 ug/mL
Compound 3 was reported as a limit; the forecaster's own chance of this, stated with the estimate: 80%; the middle value does not contradict the limit.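

In this assay, going by these compounds alone, compound 3 gives > 200 ug/mL, which is a limit, so no step from compound 1 or compound 2 to compound 3 can be read. The three compounds share one limit: the limit of > 200 ug/mL in this assay, at which 3 of the 3 values shown sit.

The compounds shown leave open how far each lies beyond that limit, and whether any change on the pendant phenyl would give a readable value in this assay.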